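The source may report more compounds than this note shows. Statements on the series, on what has been measured and on what is new or still open speak of the compounds shown alone.

Among the compounds with values here, in a functional assay on MDA-MB-435 cells (Homo sapiens) for cytotoxicity, read by MTT assay, with a stated time of 72 h (on this read-out lower numbers stand for stronger inhibition and higher numbers for weaker inhibition), compound 2 `CNCCCNc1c(C(=O)NCc2ccc(F)cc2)nc(Br)c2cccnc12` gives 11000 nM, the only actual number available so far. Compound 1 `O=C(NCc1ccc(F)cc1)c1nc(Br)c2cccnc2c1NCc1ccc(F)cc1` gives > 20000 nM, and this value is a limit of the assay. Compound 3 `O=C(NCc1ccc(F)cc1)c1nc(Br)c2cccnc2c1NCc1ccccc1` differs from compound 2 by phenyl in place of 2-(methylamino)ethyl on a saturated chain carbon bound to a nitrogen on an aromatic ring. Within the data shown here, one measured step bears on this change, namely an at least 1.8-fold lower number from compound 1 to compound 2 (0.25 log units; that floor lies within the scatter). On these data alone, its true size remains open, as only a floor is known. Compound 3 has phenyl where compound 1 has 4-fluorophenyl, so the change largely runs that step in reverse and points towards a higher number in this assay. The expected step is a 2.0-fold higher number from compound 2 to compound 3 (0.30 log units; within the scatter). Compound 3 is estimated at 22000 nM, with an expected range of 11000 nM to 45000 nM.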

Compound 3, half-maximal inhibitory concentration: > 20000 nM
Compound 3: a limit, no number (the forecaster's own chance of this, stated with the estimate: 65%); the middle value lies beyond the limit too.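

With phenyl in place of 2-(methylamino)ethyl on a saturated chain carbon bound to a nitrogen on an aromatic ring, this assay gives an at least 1.8-fold higher number from compound 2 to compound 3 (0.25 log units; that floor lies within the scatter). Removing the fluoro group from the aromatic ring therefore does not bring the benzylamino compound to a measurable number, and the step from compound 1 to compound 3 cannot be read, as both values are limits of the assay. Among these three compounds, only the one with the 3-(methylamino)propyl chain gives an actual number, and the limit constrains what the series can show: the limit of > 20000 nM in this assay, at which 2 of the 3 values shown sit.

On these data alone, how far compound 1 and compound 3 lie past that limit remains open. Also open, as far as these compounds go, is how a primary amine, a dimethylamino group or a longer chain at this place would compare with compound 2 at 11000 nM.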